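Oxindole thiosemicarbazones: chloro to fluoro on the core

The source may report more compounds than this note shows. Statements on the series, on what has been measured and on what is new or still open speak of the compounds shown alone.

Measured compounds:
compound 1 `O=C1Nc2ccc(Cl)cc2/C1=N/NC(=S)Nc1ccc(Cl)cc1` — 108000 nM
compound 2 `Cc1ccc(NC(=S)N/N=C2\C(=O)Nc3ccc(F)cc32)cc1` — 8200 nM
compound 3 `Cc1ccc(NC(=S)N/N=C2\C(=O)Nc3cc(Cl)c(F)cc32)cc1` — 166000 nM

In a functional assay on L1210 cells (Mus musculus), with a stated time of 48 h (a higher number here means a weaker inhibitor, a lower number a stronger inhibitor), compound 1 stands second highest of the three numbers. Its nearest neighbour is compound 3, whose number is within the scatter of that of compound 1; furthest away is compound 2, which gives a number beyond the scatter lower.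

Compound 4 `O=C1Nc2ccc(F)cc2/C1=N/NC(=S)Nc1ccc(Cl)cc1` is not yet measured. It differs from compound 1 by fluoro in place of chloro on an aromatic carbon.

Within the data shown here, no measured step covers this exchange directly. Compound 2 and compound 3 share the aryl thiosemicarbazide part and differ only on the core, and the step of a 20-fold higher number from compound 2 to compound 3 (1.31 log units; beyond the scatter) shows that a halogen change on that ring can shift this assay by a large amount. Compound 2, which carries fluoro on the core, gives the lowest number of the three, but it also differs from compound 1 in the aryl group, so its value alone cannot fix the size of the chloro-to-fluoro step. Given the large swings seen on this ring, a step beyond the scatter in either direction is plausible; a downward step is weakly favoured because compound 2 gives 8200 nM with fluoro in place. Compound 4 is therefore estimated at 40000 nM in this assay, with a range of 8000 nM to 200000 nM, meaning an expected step of a 2.7-fold lower number from compound 1 to compound 4 (0.43 log units; beyond the scatter).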

Compound 4, half-maximal inhibitory concentration: 34000 nM
Estimate against measurement, compound 4: 1.2-fold (0.07 log units) above; the measured number falls inside the stated range.
By their numbers in this assay, from the lowest: compound 2; then compound 4; then compounds 1 and 3 (each within the scatter of the next).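

In this assay, among these compounds, fluoro in place of chloro on the aromatic carbon of the core gives a 3.2-fold lower number from compound 1 to compound 4 (0.50 log units; beyond the scatter) with the aryl group held constant, the first direct reading of this exchange. With fluoro held on the core, chloro in place of methyl on the aryl group gives a 4.1-fold higher number from compound 2 to compound 4 (0.62 log units; beyond the scatter) and thus shows that the number also responds to the group on the far aryl ring, not only to halogens on the core. Both steps are modest beside the large one, a 20-fold higher number from compound 2 to compound 3 (1.31 log units; beyond the scatter) on adding chloro to the core, so among these compounds the biggest shift remains the one on the core of compound 2.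

The compounds shown leave open whether the fluoro-for-chloro step keeps its size with methyl on the aryl group, and how a methoxy group or an amine at this core carbon would compare with fluoro and chloro. Nothing shown gives a reason for the size or direction of either new step.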